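A few compounds are considered here, and "the series" means these few. Any claim that something is new, unique, unknown or untested is made for them only; others in the source may bear on it.

In an assay on cells with melanin-concentrating hormone receptor 1 (Homo sapiens) as the target, read by radioligand binding (on this read-out higher numbers stand for weaker inhibition and lower numbers for stronger inhibition), compound 1 `CCCCOc1cccc2ccc(N)nc12` gives 789 nM. Compound 2 `COCCOCCOc1cccc2ccc(N)nc12` gives > 2000 nM, which is a limit of the assay and not a number, as recorded in the limit of > 2000 nM in this assay, at which 1 of the 2 values shown sits. Within the data shown here, the one measured step, an at least 2.5-fold higher number from compound 1 to compound 2 (0.40 log units; beyond the scatter), therefore runs toward weaker inhibition. Compound 3 `Nc1ccc2cccc(OCC3CCOC3)c2n1` differs from compound 2 by oxolan-3-yl in place of (2-methoxyethoxy)methyl on a saturated chain carbon bound to an oxygen on an aromatic ring. The open chain ether that entered in the measured step now leaves, so a return toward the number of compound 1 is expected, and for compound 3 this means an estimated at least 1.3-fold lower number from compound 2 to compound 3 (0.12 log units; that floor lies within the scatter). Compound 3 is expected at 1500 nM, between 500 nM and 5000 nM.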

Compound 3, half-maximal inhibitory concentration: 115 nM
Estimate against measurement, compound 3: 13-fold (1.12 log units) above; the whole stated range lies above it.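

Compound 3 shows that an oxygen in this side chain can go with stronger inhibition, whereas the earlier step had paired added ether oxygens with weaker inhibition. In this assay, oxolan-3-yl brings an at least 17-fold lower number from compound 2 to compound 3 (1.24 log units; beyond the scatter), and against the open propyl chain it brings a 6.9-fold lower number from compound 1 to compound 3 (0.84 log units; beyond the scatter). The first of these steps is only a floor, because compound 2 stands at a limit of the assay and not at a number: the limit of > 2000 nM in this assay, at which 1 of the 3 values shown sits.

The compounds shown do not separate the effect of the ring from that of its oxygen. A cyclopentyl ring in the same place would address that, and a six-membered oxane ring would test the ring size.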